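From Acetyl to Methyl on the Aromatic Oxygen

The source may report more compounds than this note shows. Statements on the series, on what has been measured and on what is new or still open speak of the compounds shown alone.

The series shares one core, shown in compound 1 `CC(=O)Oc1ccc2oc(/C=C/[S+](C)[O-])cc(=O)c2c1`, and varies the group carried on an oxygen on an aromatic ring. In a functional assay on DLD-1 cells (Homo sapiens) for cytotoxicity, with a stated time of 48 h (on this read-out higher numbers stand for weaker inhibition and lower numbers for stronger inhibition), compound 1 gives only a limit, > 10000 nM, not a number. Compound 2 `CC(C)CC(=O)Oc1ccc2oc(/C=C/[S+](C)[O-])cc(=O)c2c1`, with isopropyl in place of hydrogen on a saturated chain carbon bound to a carbonyl carbon, gives 6100 nM in this assay, a change of an at least 1.6-fold lower number from compound 1 to compound 2 (0.21 log units; that floor lies within the scatter). Compound 3 `CC(C)CCOc1ccc2oc(/C=C/[S+](C)[O-])cc(=O)c2c1`, carrying isopentyl in place of acetyl on that oxygen, gives 4100 nM, which is an at least 2.4-fold lower number from compound 1 to compound 3 (0.38 log units; beyond the scatter); between compound 2 and compound 3 the step is a 1.5-fold lower number from compound 2 to compound 3 (0.17 log units; within the scatter).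

Compound 4 `COc1ccc2oc(/C=C/[S+](C)[O-])cc(=O)c2c1` has not yet been measured. It differs from compound 1 as follows: methyl in place of acetyl on an oxygen on an aromatic ring. Going by the values given here, the measured steps from compound 1 to compound 2 and to compound 3 both go toward larger groups on that oxygen, and the second clearly lowers the number; compound 4 goes the other way, to a methyl, and no measured step covers that direction. Compound 1 sits at the limit of the assay (the limit of > 10000 nM in this assay, at which 1 of the 3 values shown sits). Any estimate is therefore anchored only to a floor. For compound 4 the number is expected to stay near that of compound 1, with a step of an at least 1.1-fold lower number from compound 1 to compound 4 (0.04 log units; that floor lies within the scatter) that is likely inside the scatter, and with a fair chance that only a limit is reported again. Compound 4 is estimated at 9000 nM, in the range 3500 nM to 25000 nM.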

Compound 4, half-maximal inhibitory concentration: 5700 nM
Estimate against measurement, compound 4: 1.6-fold (0.20 log units) above, and the stated range covers the measured number.
By their numbers in this assay, from the lowest: compounds 3, 4 and 2 (each within the scatter of the next). At a limit, above all of these: compound 1.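

With methyl in place of acetyl on an oxygen on an aromatic ring, this assay shows an at least 1.7-fold lower number from compound 1 to compound 4 (0.24 log units; that floor lies within the scatter). Enlarging the group on this oxygen brings no visible gain over methyl, since the comparison with isopentyl gives a 1.4-fold higher number from compound 3 to compound 4 (0.14 log units; within the scatter), and the comparison with isobutylcarbonyl gives a 1.1-fold lower number from compound 2 to compound 4 (0.03 log units; within the scatter), so these three groups cannot be told apart in this assay. The earlier compounds carried only groups larger than acetyl, whereas compound 4 shows that a group with fewer heavy atoms than acetyl also gives a measured number, which leaves compound 1, with its acetyl, as the only one of the four held at a limit: the limit of > 10000 nM in this assay, at which 1 of the 4 values shown sits.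

How far compound 1 really stands from the other three cannot be read from a limit, and its floor to compound 4 does not pass the usual scatter. Whether a free hydroxyl, an amine or a carboxylic acid on a chain at this oxygen would move the number beyond the scatter remains open in the compounds shown.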